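This account rests on a few compounds, and the source may have more. Where it says the series, first, only, none or still open, it means among the compounds named here.

Compound 1 `CC(=O)c1nc([N+](=O)[O-])c(Sc2c(Cl)cncc2Cl)s1` gives 670 nM in an assay on isolated protein for inhibition of ubiquitin carboxyl-terminal hydrolase 7 (Homo sapiens), read by fluorescence, with stated times of 30 min and 3 h; on this read-out lower numbers stand for stronger inhibition and higher numbers for weaker inhibition. Within the data shown here, compound 2 `O=C(NCc1ccccc1)c1nc([N+](=O)[O-])c(Sc2c(Cl)cncc2Cl)s1` gives 4210 nM, the higher of the two numbers in this assay; the only measured step, a 6.3-fold higher number from compound 1 to compound 2 (0.80 log units; beyond the scatter), concerns the amide substituent as a whole. Compound 3 `O=C(NCc1ccc(F)cc1)c1nc([N+](=O)[O-])c(Sc2c(Cl)cncc2Cl)s1` differs from compound 2 by fluoro in place of hydrogen on an aromatic carbon. Among the measured compounds shown here, no measured step touches a change on the benzyl group, so nothing points in either direction, and the step of a 1.1-fold lower number from compound 2 to compound 3 (0.02 log units; within the scatter) is expected to stay within the scatter. Compound 3 is accordingly estimated at 4000 nM, with a range of 1800 nM to 9000 nM.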

Compound 3, half-maximal inhibitory concentration: 2650 nM
The estimate for compound 3 lay 1.5-fold (0.18 log units) above the measured number; low and high end bracket the measured number.
By their numbers in this assay, from the lowest: compound 1; then compounds 3 and 2 (each within the scatter of the next).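

In this assay, among these compounds, the change from benzyl to 4-fluorobenzyl gives the first reading on the aromatic ring of the amide substituent: a 1.6-fold lower number from compound 2 to compound 3 (0.20 log units; within the scatter). A single fluoro at this place therefore does not separate the two amides, and the gap to the acetyl compound remains with the fluorinated one: a 4.0-fold higher number from compound 1 to compound 3 (0.60 log units; beyond the scatter). No available evidence bears on this result.

From the compounds shown here alone, whether a methoxy, trifluoromethyl or aminomethyl group at this same place would move the number beyond the scatter stays open. So does whether a directly attached phenyl on the amide nitrogen, without the benzyl carbon, would narrow the gap to compound 1.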